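Permeability notes: compound 2 and the hydroxy analogue

This account rests on a few compounds, and the source may have more. Where it says the series, first, only, none or still open, it means among the compounds named here.

Measured so far:
compound 1 `O=C(Nc1ccc([N+](=O)[O-])c(Cl)c1)c1cc(Cl)ccc1O`: 12.3 10^-6 cm/s
compound 2 `O=C(Nc1cccc(F)c1)c1cc(Cl)ccc1O`: 3.7 10^-6 cm/s

In an ADME assay for permeability, using PAMPA, with a stated time of 3 h (a higher number here means that the compound crosses the layer faster, a lower number that the compound crosses the layer more slowly), compound 1 gives 12.3 10^-6 cm/s, while compound 2 gives 3.7 10^-6 cm/s. Compound 2 stands lowest of the two numbers; compound 1 sits above it by a margin beyond the usual scatter. Compound 3 `O=C(Nc1cccc(O)c1)c1cc(Cl)ccc1O` is not yet measured. It differs from compound 2 in one place (hydroxy in place of fluoro on an aromatic carbon). Within the data shown here, no measured pair shows this same change, so nothing among the measured compounds sizes the step; the expectation rests on compound 2 alone, anchored on its value of 3.7 10^-6 cm/s in this assay. A modest downward step is expected, a 1.9-fold lower number from compound 2 to compound 3 (0.27 log units; within the scatter), roughly at the edge of the scatter rather than clearly beyond it. Compound 3 is therefore estimated at 2 10^-6 cm/s in this assay, with a range from 0.8 10^-6 cm/s to 5 10^-6 cm/s.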

Compound 3, apparent permeability: 15.9 10^-6 cm/s
Estimate against measurement, compound 3: 8.0-fold (0.90 log units) below; the measured number lies above the stated range.
By their numbers in this assay, from the lowest: compound 2; then compounds 1 and 3 (each within the scatter of the next).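

In this assay, among these compounds, hydroxy in place of fluoro on an aromatic carbon, meta to a large group, gives a 4.3-fold higher number from compound 2 to compound 3 (0.63 log units; beyond the scatter), the first single-place step and evidence that the number responds to a change at this position. Here the entering group counts one hydrogen-bond donor and one hydrogen-bond acceptor against none for the leaving group, yet the number rises; this rests on one pair and sets no rule for the series. Nothing measured here bears on the reason for this step.

As far as these compounds go, it remains open whether an amine or a carboxylic acid at the same place would give a number nearer that of compound 2 or that of compound 3. Also open, from the compounds shown here alone, is whether the same exchange gives a step of similar size and direction at another position on the ring.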